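Replacing the cyclopropylsulfonyl cap: notes toward compound 4

This account rests on a few compounds, and the source may have more. Where it says the series, first, only, none or still open, it means among the compounds named here.

Compound 1 `CCN(CC)c1ccc2cc(C(=O)c3ccc(N4CCN(C(=O)CN5CCN(C(=O)CCl)CC5)CC4)cc3)oc2c1`: 1630 nM in a functional assay on SGC-7901 cells (Homo sapiens) for cytotoxicity, read by MTT assay, with a stated time of 48 h; on this read-out higher numbers stand for weaker inhibition and lower numbers for stronger inhibition
Compound 2 `CCN(CC)c1ccc2cc(C(=O)c3ccc(N4CCN(C(=O)CN5CCN(C(=O)/C=C/c6ccccc6)CC5)CC4)cc3)oc2c1`: 1140 nM in this assay
Compound 3 `CCN(CC)c1ccc2cc(C(=O)c3ccc(N4CCN(C(=O)CN5CCN(S(=O)(=O)C6CC6)CC5)CC4)cc3)oc2c1`: 15300 nM in this assay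

Compound 3 gives the highest number of the three: its nearest neighbour is compound 1, a 9.4-fold higher number from compound 1 to compound 3 (0.97 log units; beyond the scatter), and the furthest is compound 2, a 13-fold higher number from compound 2 to compound 3 (1.13 log units; beyond the scatter). Compound 4 `CCN(CC)c1ccc2cc(C(=O)c3ccc(N4CCN(C(=O)CN5CCN(S(=O)(=O)c6ccc(OC(F)(F)F)cc6)CC5)CC4)cc3)oc2c1` differs from compound 3 in one place: 4-(trifluoromethoxy)phenyl in place of cyclopropyl on a sulfonyl sulfur. Neither measured step touches the group on the sulfonyl sulfur; both replace the whole cap on the amine nitrogen in the ring, and both carbonyl caps gave markedly lower numbers than the sulfonyl cap of compound 3. Going by the values given here, with no step of the present kind measured, the expectation for compound 4 in this assay is a change no larger than the scatter, a 1.3-fold lower number from compound 3 to compound 4 (0.11 log units; within the scatter), in either direction. Compound 4 is estimated at 12000 nM, within 4000 nM to 35000 nM.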

Compound 4, half-maximal inhibitory concentration: 24400 nM
Beside the measured number, compound 4's estimate is 2.0-fold (0.31 log units) below it; the measured number falls inside the stated range.
By their numbers in this assay, from the lowest: compounds 2 and 1 (each within the scatter of the next); then compounds 3 and 4 (each within the scatter of the next).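

In this assay, 4-(trifluoromethoxy)phenyl in place of cyclopropyl on the sulfonyl sulfur gives a 1.6-fold higher number from compound 3 to compound 4 (0.20 log units; within the scatter). Going by these compounds alone, an aromatic group of 11 heavy atoms and a three-membered ring of 3 heavy atoms therefore give numbers within the scatter of each other at this position, the first reading of a change on the sulfur itself. No available data explain this result.

Still open, as far as these compounds go, is whether an amine or a carboxylic acid on the sulfonyl sulfur would move the number beyond the scatter. A longer chain there is equally untested by the compounds shown.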